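Swapping thiophen-2-yl for furan-2-yl in compound 2

The source may report more compounds than this note shows. Statements on the series, on what has been measured and on what is new or still open speak of the compounds shown alone.

- Compound 1 `O=C(N/N=C1\C[C@@H](c2ccc(O)cc2)Oc2cc(O)cc(O)c21)c1ccco1` gives >= 11300 nM (a limit)
- Compound 2 `COc1cc(O)c2c(c1)O[C@H](c1ccc(O)cc1)C/C2=N\NC(=O)c1cccs1` gives 9400 nM

Both compounds were tested in a functional assay on L5178Y cells (Mus musculus) for inhibition, read by MTT assay, with a stated time of 24 h; on this read-out lower numbers stand for stronger inhibition and higher numbers for weaker inhibition. Going by the values given here, compound 2 gives 9400 nM, the only true number available so far. The other result, for compound 1, is >= 11300 nM, which is a limit and not a number. Compound 2 therefore has no measured number to be ranked against.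

Compound 3 `COc1cc(O)c2c(c1)O[C@H](c1ccc(O)cc1)C/C2=N\NC(=O)c1ccco1` has not been measured yet. It carries furan-2-yl in place of thiophen-2-yl on a carbonyl carbon. Among the compounds with values here, no measured pair shows this exchange. Each group is a five-membered aromatic ring with 1 hetero atom, and no step beyond the usual scatter is expected in this assay, in either direction. The expected result is a 1.1-fold higher number from compound 2 to compound 3 (0.05 log units; within the scatter). For compound 3 the estimate is 10500 nM, with an expected range from 5000 nM to 22000 nM.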

Compound 3, half-maximal inhibitory concentration: >= 11300 nM
Compound 3: only a limit was reported; the forecaster's own chance of this, stated with the estimate: 30%; middle value at least 1.0-fold (0.03 log units) away from the limit.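

Furan-2-yl in place of thiophen-2-yl on a carbonyl carbon now has a measured pair, and in this assay it gives an at least 1.2-fold higher number from compound 2 to compound 3 (0.07 log units; that floor lies within the scatter). No real difference between the two rings can be claimed yet, because the step is only a floor set by a limit and not by a number: the limit of >= 11300 nM in this assay, at which 2 of the 3 values shown sit.

The step between compound 1 and compound 3, methyl in place of hydrogen on an oxygen on an aromatic ring, cannot be read: both compounds sit at limits.

On these data alone, how far compound 3 really lies from compound 2 stays open. A different group on the carbonyl carbon, such as a phenyl ring or an amine, could show whether the number moves beyond the scatter with something other than a five-membered aromatic ring with 1 hetero atom.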